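The compounds below may be only part of what the source reports. "The series", "measured", "known", "first", "only" and "open" are said of these compounds alone.

Measured compounds:
Compound 1, `O=C(/C(=C\c1c(-c2ccccc2)[nH]c2ccccc12)S(=O)(=O)c1ccccc1)c1ccccc1`: in a functional assay on MDA-MB-435 cells (Homo sapiens) for inhibition, read by sulforhodamine B assay, with a stated time of 48 h (on this read-out lower numbers stand for stronger inhibition of growth and higher numbers for weaker inhibition of growth), compound 1 gives 3900 nM.
Compound 2, `N#C/C(=C\c1c(-c2ccccc2)[nH]c2ccccc12)S(=O)(=O)c1ccccc1`: in this assay compound 2 gives 288 nM.

Compound 2 holds the lowest of the two numbers shown; its nearest neighbour is compound 1, and the step of a 14-fold lower number from compound 1 to compound 2 (1.13 log units; beyond the scatter) separates them. Compound 3, `N#C/C(=C\c1c(-c2ccccc2)[nH]c2ccccc12)C(=O)c1ccccc1`, keeps the cyano group of compound 2 but carries benzoyl in place of phenylsulfonyl on a double-bonded chain carbon bound to a double-bonded chain carbon and a triple-bonded carbon. Going by the values given here, no measured pair shows this exchange directly: the only step on record, a 14-fold lower number from compound 1 to compound 2 (1.13 log units; beyond the scatter), concerns the other substituent on that chain carbon and was large. It tells that the carbon bearing the two groups is sensitive to what sits on it, but not in which direction a sulfonyl-to-benzoyl swap would move the number. Compound 3 is therefore expected to land somewhere between the values of compound 1 and compound 2, with the step of a 2.4-fold higher number from compound 2 to compound 3 (0.39 log units; beyond the scatter) regarded as uncertain in direction. Her estimate for compound 3 in this assay is 700 nM, with a range from 150 nM to 3500 nM.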

Compound 3, concentration for 50% growth inhibition: 370 nM
Estimate against measurement, compound 3: 1.9-fold (0.28 log units) above; the range from low to high includes it.
By their numbers in this assay, from the lowest: compounds 2 and 3 (each within the scatter of the next); then compound 1.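

In this assay the exchange of phenylsulfonyl for benzoyl on a double-bonded chain carbon bound to a double-bonded chain carbon and a triple-bonded carbon gives a 1.3-fold higher number from compound 2 to compound 3 (0.11 log units; within the scatter) so, with the cyano group in place, the assay does not separate these two groups at this position. The earlier step, a 14-fold lower number from compound 1 to compound 2 (1.13 log units; beyond the scatter) showed only that the chain carbon responded when cyano replaced benzoyl while phenylsulfonyl stayed, whereas the new pair shows that phenylsulfonyl is not needed for a number in this range, since compound 3 gives 370 nM in this assay with benzoyl in its place. Nothing available explains why the two groups read alike.

As far as these compounds go, whether this holds for other groups on the same carbon, such as a methyl ketone, a methylsulfonyl group or an amide, remains open. From the compounds shown here alone, it is also open whether the cyano group can give way to a carboxylic acid or its methyl ester while benzoyl or phenylsulfonyl stays on the chain.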